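Swapping a Fluoroaryl Ketone for an Anilide in a Weak Series

The compounds below may be only part of what the source reports. "The series", "measured", "known", "first", "only" and "open" are said of these compounds alone.

In a functional assay on HT-29 cells (Homo sapiens) for inhibition, read by MTT assay, with a stated time of 48 h (on this read-out higher numbers stand for weaker inhibition and lower numbers for stronger inhibition), compound 3 `COc1cc(-c2nnc(SCC(=O)c3ccc(F)cc3)n2-c2ccc(N(C)C)cc2)cc(OC)c1OC` gives 78100 nM. Compound 1 `COc1ccc(NC(=O)CSc2nnc(-c3cc(OC)c(OC)c(OC)c3)n2-c2ccc(OC)cc2)cc1` gives 45300 nM, which lies within the scatter of the value for compound 3. Compound 2 `COc1cc(-c2nnc(SCc3ccccc3)n2-c2ccc(N(C)C)cc2)cc(OC)c1OC` is reported only as > 60000 nM, which is a limit and not a number.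

Compound 4 `COc1ccc(NC(=O)CSc2nnc(-c3cc(OC)c(OC)c(OC)c3)n2-c2ccc(N(C)C)cc2)cc1` differs from compound 3 in one place, with (4-methoxyphenyl)amino in place of 4-fluorophenyl on a carbonyl carbon. Among the measured compounds shown here, the only measured step is a step that the limit leaves unreadable from compound 2 to compound 3, so it offers no size to carry over. The nearest guide is the entering (4-methoxyphenyl)carbamoyl group, which compound 1 also carries, at 45300 nM. Compound 1 differs from compound 4 elsewhere as well, so this is only indirect support, but its value gives no reason to expect a shift in this assay. A result reported only as a limit also remains possible, given (the limit of > 60000 nM in this assay, at which 1 of the 3 values shown sits).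

The estimated change is a 1.4-fold lower number from compound 3 to compound 4 (0.15 log units; within the scatter), and no shift beyond the scatter is expected. For compound 4 the expected value is 55000 nM, with an estimated range from 25000 nM to 110000 nM.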

Compound 4, half-maximal inhibitory concentration: 51400 nM
Compound 4: the middle estimate sits 1.1-fold (0.03 log units) above what was measured; the range from low to high includes it.
By their numbers in this assay, from the lowest: compounds 1, 4 and 3 (each within the scatter of the next).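

Placing (4-methoxyphenyl)amino in place of 4-fluorophenyl on a carbonyl carbon produced a 1.5-fold lower number from compound 3 to compound 4 (0.18 log units; within the scatter) in this assay, so the (4-fluorophenyl)carbonyl and (4-methoxyphenyl)carbamoyl groups cannot be told apart at this position in this series. Among the compounds shown here, the compounds also give the first readable comparison of dimethylamino in place of methoxy on an aromatic carbon, with a 1.1-fold higher number from compound 1 to compound 4 (0.05 log units; within the scatter), and this change likewise brings no shift beyond the scatter. Compound 2 stands only as a limit, and (4-methoxyphenyl)carbamoyl in place of phenyl on a saturated chain carbon bound to a sulfur gives an at least 1.1-fold lower number from compound 2 to compound 4 (0.06 log units; that floor lies within the scatter), which is a floor and not a measured size: the limit of > 60000 nM in this assay, at which 1 of the 4 values shown sits.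

The compounds shown leave open whether any group on this carbonyl carbon can move the value beyond the scatter, for instance an amine such as piperidine or a carboxylic acid on a longer chain. They also leave open whether dimethylamino and methoxy would stay indistinguishable on a compound whose other parts differ from those of compound 1 and compound 4.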